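Adding a cyano group to compound 1

This account rests on a few compounds, and the source may have more. Where it says the series, first, only, none or still open, it means among the compounds named here.

Compound 1 `C=CS(=O)(=O)N1CCN(c2ncnc3sc(-c4ccccc4)cc23)CC1` gives 54200 nM
Compound 2 `C=CS(=O)(=O)N1CCN(c2ccn3ncc(-c4ccccc4)c3n2)CC1` gives 38300 nM
Compound 3 `C=CS(=O)(=O)N1CCN(c2ncnc3ccc(-c4ccccc4)cc23)CC1` gives 47900 nM

All three values come from a functional assay on MDA-MB-231 cells (Homo sapiens) for antiproliferative activity, read by MTT assay, with a stated time of 48 h (on this read-out higher numbers stand for weaker inhibition and lower numbers for stronger inhibition), and lie within the usual scatter of one another, so compound 1 cannot be told apart from compound 2 or compound 3, although their cores differ. Compound 4 `C=CS(=O)(=O)N1CCN(c2ncnc3sc(-c4ccc(C#N)cc4)cc23)CC1` is compound 1 with cyano in place of hydrogen on an aromatic carbon, para to a large group (cyano in place of hydrogen on an aromatic carbon). Among the measured compounds shown here, no measured pair shows a change of this kind, so the expectation rests on judgement alone. For the measured compounds named here, a modest move toward stronger inhibition is expected, an estimated 2.2-fold lower number from compound 1 to compound 4 (0.34 log units; beyond the scatter) in this assay with no measured step behind it. For compound 4 the estimated value is 25000 nM (expected range 9000 nM to 60000 nM).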

Compound 4, half-maximal inhibitory concentration: 8050 nM
Compound 4: the middle estimate sits 3.1-fold (0.49 log units) above what was measured, outside the stated range (below it).
By their numbers in this assay, from the lowest: compound 4; then compounds 2, 3 and 1 (each within the scatter of the next).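

In this assay, the change from phenyl to 4-cyanophenyl gives a 6.7-fold lower number from compound 1 to compound 4 (0.83 log units; beyond the scatter) and so shows that this position on the aromatic ring responds to substitution. The three earlier compounds, which differ in their cores and lie within the scatter of one another, could not show this. Nothing measured here accounts for the step.

From the compounds shown here alone, it remains open whether the step belongs to cyano itself or would also follow from an amine, a carboxylic acid or a methoxy group in the same place. Going by these compounds, whether cyano would give a similar step on the cores of compound 2 and compound 3 is also open.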